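From compound 3 to compound 4: an aryl swap

A few compounds are considered here, and "the series" means these few. Any claim that something is new, unique, unknown or untested is made for them only; others in the source may bear on it.

Measured so far in a functional assay on BT-549 cells (Homo sapiens) for cytotoxicity, read by sulforhodamine B assay, with a stated time of 72 h (on this read-out higher numbers stand for weaker inhibition and lower numbers for stronger inhibition), are these compounds
- compound 1 `CCS(=O)(=O)Nc1cc(-c2ccc3ncnc(Nc4cccc(F)c4)c3c2)cnc1OC` gives 2760 nM here
- compound 2 `CCS(=O)(=O)Nc1cc(-c2ccc3ncnc(Nc4ccc(OC)cc4)c3c2)cnc1OC` gives 1880 nM here
- compound 3 `CCS(=O)(=O)Nc1cc(-c2ccc3ncnc(Nc4ccc(OC)c(Cl)c4)c3c2)cnc1OC` gives 2470 nM here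

Compound 3 stands within the scatter of both other compounds in this assay and is not separated from either. The next case is compound 4 `CCS(=O)(=O)Nc1cc(-c2ccc3ncnc(Nc4cccc(C(=O)OC)c4)c3c2)cnc1OC` and the change is 3-(methoxycarbonyl)phenyl in place of 3-chloro-4-methoxyphenyl on a nitrogen on an aromatic ring or, in words, 3-(methoxycarbonyl)phenyl in place of 3-chloro-4-methoxyphenyl on a nitrogen on an aromatic ring.

The steps at this same place are a 1.5-fold lower number from compound 1 to compound 2 (0.17 log units; within the scatter) and a 1.1-fold lower number from compound 1 to compound 3 (0.05 log units; within the scatter) and both stay within the scatter. The chloro step, a 1.3-fold higher number from compound 2 to compound 3 (0.12 log units; within the scatter) in size, also stays within it. Within the data shown here, none of these steps brings in a methoxycarbonyl group, so the data hold no direct precedent. No step beyond the scatter is expected, and the estimated change is a 1.1-fold lower number from compound 3 to compound 4 (0.03 log units; within the scatter) with no firm direction. The estimate for compound 4 is 2300 nM with an expected range from 1000 nM to 5500 nM in this read-out.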

Compound 4, half-maximal inhibitory concentration: 1080 nM
Estimate against measurement, compound 4: 2.1-fold (0.33 log units) above; the measured number falls inside the stated range.
By their numbers in this assay, from the lowest: compounds 4, 2, 3 and 1 (each within the scatter of the next, the first and the last beyond it).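

In this assay, among these compounds, the aryl group on this nitrogen now gives steps beyond the scatter, which no earlier step at this place did: a 2.3-fold lower number from compound 3 to compound 4 (0.36 log units; beyond the scatter) and a 2.6-fold lower number from compound 1 to compound 4 (0.41 log units; beyond the scatter), both modest. The second is the cleaner reading, as methoxycarbonyl replaces fluoro on an aromatic carbon and the rest of the compound stays the same. With a 1.7-fold lower number from compound 2 to compound 4 (0.24 log units; within the scatter) inside the scatter, 3-(methoxycarbonyl)phenyl is separated from 3-chloro-4-methoxyphenyl and 3-fluorophenyl but not from 4-methoxyphenyl.

Open, from the compounds shown here alone, is whether the lower number needs the methyl ester itself, or would hold with a carboxylic acid, a primary amide or an ethyl ester in its place. Also open, going by these compounds, is whether a second methoxycarbonyl-bearing aryl group, or a chloro added to this one, would move the number further.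

Nothing available bears on why these steps occur.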